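This account rests on a few compounds, and the source may have more. Where it says the series, first, only, none or still open, it means among the compounds named here.

Measured so far:
- compound 1, `C[C@@H](Sc1nc2c(cnn2C)c(=O)n1-c1ccccc1)c1ccccc1`, gives "active" (no number reported); 71% (2 entries) in an assay on PEO1 cells for inhibition of Retinaldehyde dehydrogenase 3 (Homo sapiens), read by flow cytometry, with a stated time of 30 min, tested at 1 uM; a higher number here means more inhibition at the concentration tested (going by the name of the read-out), a lower number less inhibition
- compound 2, `CC(Sc1nc2c(cnn2C)c(=O)n1-c1ccccc1)c1ccccn1`, gives 97% in this assay

Compound 1 has more than one entry; the several entries of compound 1 in this assay, "active" (no number reported); 71% (2 entries) shows that one of its entries carries no number at all. Among the measured compounds shown here, compound 2 is the only other compound with a single number, and that number stands higher than the one reported for compound 1. The unmeasured compound 3, `CC(Sc1nc2c(cnn2C)c(=O)n1-c1ccccc1)c1cccnc1`, keeps everything of compound 2 except the ring hung on the chain: pyridin-3-yl in place of pyridin-2-yl on a saturated chain carbon bound to a saturated chain carbon and a sulfur. Both rings carry the same atoms, only joined differently, so no large move in this assay is expected; the step from compound 2 to compound 3 is expected to stay close to the scatter, if anything downward, as a number 12 percentage points lower from compound 2 to compound 3 (beyond the scatter). For compound 3 the expected value in this assay is 85%, with a likely range from 60% to 99%.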

Compound 3, a percentage reported as inhibition, at one concentration (the size of the read-out at that concentration, not a potency): 95%
The estimate for compound 3 lay 10 percentage points below the measured number, within the range that was stated.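

Swapping pyridin-2-yl for pyridin-3-yl on this saturated chain carbon makes no readable difference in this assay, with a number 2 percentage points lower from compound 2 to compound 3 (within the scatter). So this place now has two ring attachments with a number, and the assay does not tell them apart, though each is a read-out at one concentration and not a potency, which leaves any gap in potency between them unseen. Nothing among the measurements shown gives a reason for this result.

The compounds shown leave open how pyridin-4-yl would read at this place, and whether a carboxylic acid or an amine on the ring would be accepted as well. A longer chain in place of the 1-(pyridin-3-yl)ethyl link also remains untested among these compounds.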